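A few compounds are considered here, and "the series" means these few. Any claim that something is new, unique, unknown or untested is made for them only; others in the source may bear on it.

Measured in a functional assay on HL-60 cells (Homo sapiens) for cytotoxicity, read by ELISA, with a stated time of 2 days; on this read-out higher numbers stand for weaker inhibition and lower numbers for stronger inhibition:
- compound 1 `Oc1cccc(-c2cc(-c3ccccc3)nc(-c3cccs3)c2)c1`: 18900 nM
- compound 2 `Oc1cccc(-c2cc(-c3ccccc3)nc(-c3ccsc3)c2)c1`: 12000 nM
- compound 3 `Oc1cccc(-c2cc(-c3ccccc3)nc(-c3cccnc3)c2)c1`: 12600 nM

On these numbers, compound 3 cannot be told apart from the other two compounds. The steps of a 1.5-fold lower number from compound 1 to compound 3 (0.18 log units; within the scatter) and a 1.1-fold higher number from compound 2 to compound 3 (0.02 log units; within the scatter) both lie within the scatter, as does a 1.6-fold lower number from compound 1 to compound 2 (0.20 log units; within the scatter).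

Compound 4 `Oc1cccc(-c2cc(-c3ccccc3)nc(-c3ccncc3)c2)c1` differs from compound 3 in one ring: pyridin-4-yl in place of pyridin-3-yl on an aromatic carbon. All three measured steps exchange the ring at this same place, so they bear directly on the change, and none goes beyond the scatter. Within the data shown here, no measured compound carries pyridin-4-yl, so no step beyond the scatter is expected in this assay, though this remains untested.

The estimated change is a 1.0-fold higher number from compound 3 to compound 4 (0.01 log units; within the scatter).

For compound 4 the estimated value is 13000 nM, with an expected range from 7000 nM to 24000 nM.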

Compound 4, half-maximal inhibitory concentration: 12700 nM
Compound 4: middle estimate off by 1.0-fold (0.01 log units), on the high side; the range from low to high includes it.
By their numbers in this assay, from the lowest: compounds 2, 3, 4 and 1 (each within the scatter of the next).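

In this assay, among these compounds, pyridin-4-yl in place of pyridin-3-yl leaves the number within the scatter (a 1.0-fold higher number from compound 3 to compound 4 (0.00 log units; within the scatter)), so this is the first sign that shifting the nitrogen within the six-membered ring makes no readable difference at this place. Pyridin-4-yl also cannot be told apart from either thiophene (a 1.1-fold higher number from compound 2 to compound 4 (0.02 log units; within the scatter); a 1.5-fold lower number from compound 1 to compound 4 (0.17 log units; within the scatter)), which extends the flat picture to all four rings. Nothing available explains this sameness.

As far as these compounds go, whether an amine, a carboxylic acid or a longer alkyl chain at this place would give a step beyond the scatter remains open.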